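From 2-Nitrophenyl to 4-Chlorophenyl on a Sulfonyl Sulfur

This account rests on a few compounds, and the source may have more. Where it says the series, first, only, none or still open, it means among the compounds named here.

- compound 1 `N#C/C(=C\c1ccccc1OS(=O)(=O)c1ccc([N+](=O)[O-])cc1)C(=O)Nc1nnc(Cc2ccc(F)cc2)s1`: 18%
- compound 2 `N#C/C(=C\c1ccccc1OS(=O)(=O)c1ccccc1[N+](=O)[O-])C(=O)Nc1nnc(Cc2ccc(F)cc2)s1`: 35%

In a functional assay on HL-60 cells (Homo sapiens) for inhibition, read by CCK-8 assay, with a stated time of 48 h, tested at 20 uM (on this read-out lower numbers stand for less inhibition of growth and higher numbers for more inhibition of growth at the one concentration tested), compound 2 stands higher of the two measured compounds at 35%. The next compound, compound 3 `N#C/C(=C\c1ccccc1OS(=O)(=O)c1ccc(Cl)cc1)C(=O)Nc1nnc(Cc2ccc(F)cc2)s1`, departs from it by one exchange: 4-chlorophenyl in place of 2-nitrophenyl on a sulfonyl sulfur. Put simply, it carries 4-chlorophenyl in place of 2-nitrophenyl on a sulfonyl sulfur.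

For the measured compounds named here, only one measured step bears on this place, a number 17 percentage points higher from compound 1 to compound 2 (beyond the scatter), and it was modest. That step exchanged 4-nitrophenyl for 2-nitrophenyl, so it shows that the group at this place can move the read-out. Going by the values given here, no measured compound carries 4-chlorophenyl, and the data do not show how it compares directly with either nitrophenyl group. The name of the entering group shares its number with the 4-nitrophenyl of compound 1, at 18%, so the expectation leans towards that value without reaching it. A modest fall is therefore expected, and the estimated step is a number 11 percentage points lower from compound 2 to compound 3 (beyond the scatter). For compound 3 the estimated value is 24%, with an expected range from 8% to 42%.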

Compound 3, percent growth inhibition at one concentration: 20%
Beside the measured number, compound 3's estimate is 4 percentage points above it; low and high end bracket the measured number.
By their numbers in this assay, from the lowest: compounds 1 and 3 (each within the scatter of the next); then compound 2.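

In this assay, 4-chlorophenyl in place of 2-nitrophenyl on the sulfonyl sulfur gives a number 15 percentage points lower from compound 2 to compound 3 (beyond the scatter), which shows that this place responds to a change of substituent as well as to a shift of the nitro group around the ring. Chloro in place of nitro on an aromatic carbon gives a number 2 percentage points higher from compound 1 to compound 3 (within the scatter), so 4-chlorophenyl and 4-nitrophenyl cannot be told apart on this read-out, and among these three compounds only the 2-nitrophenyl of compound 2 stands clear of the others, although compound 1 shows that carrying a nitro group does not by itself bring the higher number. Nothing given here explains why the three groups fall as they do.

On these data alone, it remains open whether the higher number of compound 2 belongs to the nitro group itself or would also appear with another substituent at the same ring position. A plain phenyl, an aminophenyl or a simple methyl on the sulfonyl sulfur would show whether the aromatic ring and its substituent are needed at all at this place.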